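This account rests on a few compounds, and the source may have more. Where it says the series, first, only, none or still open, it means among the compounds named here.

Compound 1 `CCCCCCCCCCCCCC(=O)Nc1nnc(S[C@@H]2O[C@H](COC(C)=O)[C@H](OC(C)=O)[C@H](OC(C)=O)[C@H]2OC(C)=O)s1` stands at the lowest of the two numbers reported in an ADME assay on CHO-K1 cells (Cricetulus griseus) for cytotoxicity, read by MTT assay, with a stated time of 24 h (on this read-out higher numbers stand for weaker inhibition and lower numbers for stronger inhibition), where compound 1 gives 16300 nM. Compound 2 `CCCCCCCC(=O)Nc1nnc(S[C@@H]2O[C@H](CO)[C@H](O)[C@H](O)[C@H]2O)s1` gives 60100 nM in this assay, a higher number than compound 1 by a gap beyond the usual scatter. Compound 3 `CCCCCCCCCCCCCCCC(=O)Nc1nnc(S[C@@H]2O[C@H](CO)[C@H](O)[C@H](O)[C@H]2O)s1` is recorded in this assay as "not active" (no number reported), without a number. Compound 4 `C=CCCCCCCCCC(=O)Nc1nnc(S[C@@H]2O[C@H](COC(C)=O)[C@H](OC(C)=O)[C@H](OC(C)=O)[C@H]2OC(C)=O)s1` has not yet been measured; it differs from compound 1 by vinyl in place of pentyl on a saturated chain carbon, eight bonds along the chain from a carbonyl carbon. Within the data shown here, no measured pair shows this change on its own, so the expectation rests on compound 1 alone. The step of a 1.5-fold higher number from compound 1 to compound 4 (0.19 log units; within the scatter) is expected to be modest, toward a higher number, and may well fall within the scatter. In this assay compound 4 is estimated at 25000 nM, with a range from 9000 nM to 70000 nM.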

Compound 4, half-maximal inhibitory concentration: 16300 nM
Compound 4: middle estimate off by 1.5-fold (0.19 log units), on the high side, and the stated range covers the measured number.
By their numbers in this assay, from the lowest: compounds 1 and 4 (each within the scatter of the next); then compound 2.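

Vinyl in place of pentyl on a saturated chain carbon, eight bonds along the chain from a carbonyl carbon, gives no change at the digits printed from compound 1 to compound 4 (within the scatter) in this assay and is the first change in one place that can be read here. For this pair, the shorter chain ending in a double bond reads the same as the saturated chain, within the scatter. Nothing measured at hand explains this result.

Open, on these data alone, is whether a carboxylic acid or an amine at the chain end would leave the reading unchanged. Also open, as far as these compounds go, is whether vinyl behaves alike on the deacetylated sugar of compound 2.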